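The source may report more compounds than this note shows. Statements on the series, on what has been measured and on what is new or still open speak of the compounds shown alone.

Going by the values given here, of the two numbers so far in a functional assay on SW-620 cells (Homo sapiens) for inhibition, read by MTT assay, with a stated time of 48 h (on this read-out higher numbers stand for weaker inhibition and lower numbers for stronger inhibition), the one for compound 2 `Cc1ccc(NC(=S)NC(=O)c2ccc(OCc3ccc(Cl)cc3Cl)cc2)cc1-c1nc2ccccc2[nH]1` is the lower, though the gap to compound 1 falls within the scatter. In this assay compound 2 gives 57200 nM. Compound 1 `Cc1ccc(NC(=S)NC(=O)c2ccc(OCc3ccccc3)cc2)cc1-c1nc2ccccc2[nH]1` gives 67100 nM in this assay. Among the compounds with values here, the only measured step, a 1.2-fold lower number from compound 1 to compound 2 (0.07 log units; within the scatter), stayed within the scatter. Compound 3 `O=C(NC(=S)Nc1ccc(Cl)c(-c2nc3ccccc3[nH]2)c1)c1ccc(OCc2ccc(Cl)cc2Cl)cc1` differs from compound 2 by chloro in place of methyl on an aromatic carbon. Within the data shown here, no measured step touches this place, so nothing beyond the scatter is expected, an estimated step of a 1.0-fold lower number from compound 2 to compound 3 (0.02 log units; within the scatter). Compound 3 is expected to give about 55000 nM in this assay, in the range 25000 nM to 120000 nM.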

Compound 3, half-maximal inhibitory concentration: 50200 nM
For compound 3 the middle estimate is 1.1-fold (0.04 log units) above the measured one; measured number inside the range.
By their numbers in this assay, from the lowest: compounds 3, 2 and 1 (each within the scatter of the next).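

In this assay, going by these compounds alone, chloro in place of methyl on the aromatic carbon ortho to the 1H-benzimidazol-2-yl group gives a 1.1-fold lower number from compound 2 to compound 3 (0.06 log units; within the scatter), the first reading at this position, and it shows that this exchange of one heavy atom stays within the scatter. Both single-place steps now read so, one on each side of the molecule. No evidence bearing on this result is available.

Still open, from the compounds shown here alone, is whether an amine or a carboxylic acid at this position would move the number beyond the scatter.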